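Amide variation on the shared spiro sulfone core

A few compounds are considered here, and "the series" means these few. Any claim that something is new, unique, unknown or untested is made for them only; others in the source may bear on it.

Three compounds of the series share one core and differ only at the carbonyl carbon. Compound 1 `COC(=O)C1(S(=O)(=O)c2ccc(Oc3ccc(OC(F)(F)F)cc3)cc2)CCC2(CCNCC2)C1` carries a methoxy there; in a functional assay on blood (Homo sapiens), with a stated time of 60 min, in the presence of a further agent that is not named here (on this read-out lower numbers stand for an effect already at smaller amounts and higher numbers for an effect only at larger amounts of compound), compound 1 gives > 15000 nM, which is a limit of the assay rather than a number. Compound 2 `O=C(OCc1ccccc1)C1(S(=O)(=O)c2ccc(Oc3ccc(OC(F)(F)F)cc3)cc2)CCC2(CCNCC2)C1` carries a benzyloxy; in this assay compound 2 gives > 15000 nM, again only a limit. Compound 3 `O=C(Nc1nccs1)C1(S(=O)(=O)c2ccc(Oc3ccc(OC(F)(F)F)cc3)cc2)CCC2(CCNCC2)C1` carries a (1,3-thiazol-2-yl)amino; in this assay compound 3 gives > 15000 nM, also a limit. The steps a step that the two limits leave unreadable from compound 1 to compound 2, a step that the two limits leave unreadable from compound 1 to compound 3 and a step that the two limits leave unreadable from compound 2 to compound 3 therefore cannot be sized, because every value rests at the limit of > 15000 nM in this assay, at which 3 of the 3 values shown sit.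

Compound 4 `Nc1ccc(-c2cccs2)cc1NC(=O)C1(S(=O)(=O)c2ccc(Oc3ccc(OC(F)(F)F)cc3)cc2)CCC2(CCNCC2)C1` differs from compound 3 in one place: 2-amino-5-(thiophen-2-yl)phenyl in place of 1,3-thiazol-2-yl on an amide-type nitrogen. Within the data shown here, no measured step touches the substituent on the amide-type nitrogen, so none of them bears on this change, and the expected step of an at least 1.6-fold lower number from compound 3 to compound 4 (0.22 log units; that floor lies within the scatter) rests on no measured precedent. Compound 4 is estimated at 9000 nM, within a range from 1500 nM to 30000 nM, with a real chance that compound 4 again returns only a limit.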

Compound 4, half-maximal effective concentration: 900 nM
Beside the measured number, compound 4's estimate is 10-fold (1.00 log units) above it; measured number outside the range, below it.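

The substituent on the amide-type nitrogen is a position where this assay can respond: 2-amino-5-(thiophen-2-yl)phenyl in place of 1,3-thiazol-2-yl gives an at least 16-fold lower number from compound 3 to compound 4 (1.22 log units; beyond the scatter). Going by these compounds, because the step starts from a limit, it is a floor on the change and its true size stays unknown. Compound 4 is the only compound shown that gives a number rather than a limit, and the other three compounds offer no reading of the ester or thiazolyl amide groups: the limit of > 15000 nM in this assay, at which 3 of the 4 values shown sit.

The entering group differs from 1,3-thiazol-2-yl in several features at once, so the compounds shown do not separate the contribution of the amino group from that of the thiophen-2-yl. An unsubstituted phenyl on the same nitrogen, or a phenyl carrying only the amine or only the thiophen-2-yl, would address that question.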